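A few compounds are considered here, and "the series" means these few. Any claim that something is new, unique, unknown or untested is made for them only; others in the source may bear on it.

Measured so far in a functional assay on MCF7 cells (Homo sapiens) for antiproliferative activity, read by CCK-8 assay, with a stated time of 72 h; on this read-out lower numbers stand for stronger inhibition and higher numbers for weaker inhibition:
compound 1 `COc1ccc(C(=O)Nc2cccc(-c3oc4cc(-c5ccc(F)cc5)ccc4c(=O)c3O)c2)cc1` gives 6250 nM
compound 2 `Cc1ccc(C(=O)Nc2cccc(-c3oc4cc(-c5ccc(F)cc5)ccc4c(=O)c3O)c2)cc1` gives 2400 nM
compound 3 `COc1cccc(C(=O)Nc2cccc(-c3oc4cc(-c5ccc(F)cc5)ccc4c(=O)c3O)c2)c1` gives 15300 nM

Compound 3 stands highest of the three. The cores of compound 1 and compound 3 differ by 3-methoxyphenyl in place of 4-methoxyphenyl on a carbonyl carbon, a step of a 2.4-fold higher number from compound 1 to compound 3 (0.39 log units; beyond the scatter) in this assay. Compound 4 `Cc1cccc(C(=O)Nc2cccc(-c3oc4cc(-c5ccc(F)cc5)ccc4c(=O)c3O)c2)c1` is not yet measured; it differs from compound 3 by methyl in place of methoxy on an aromatic carbon. The same kind of change occurs once among the measured pairs, from compound 1 to compound 2, as methyl in place of methoxy on an aromatic carbon, a step of a 2.6-fold lower number from compound 1 to compound 2 (0.42 log units; beyond the scatter). The two places are not the same word for word: in compound 1 the group sits para to a large group, in compound 3 it sits meta to a large group, so this is the same kind of change, not the same. Resting on that single step seen from compound 1 to compound 2, the step from compound 3 to compound 4 is expected to be a 2.6-fold lower number from compound 3 to compound 4 (0.41 log units; beyond the scatter). Compound 4 is estimated at 6000 nM, with a likely range from 3000 nM to 12000 nM.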

Compound 4, half-maximal inhibitory concentration: 7850 nM
For compound 4 the middle estimate is 1.3-fold (0.12 log units) below the measured one, and the stated range covers the measured number.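

In this assay, methyl in place of methoxy carries across the two cores with no difference between the steps: the same change on two cores in this assay, a 2.6-fold lower number (0.42 log units; beyond the scatter) from compound 1 to compound 2 and a 1.9-fold lower number (0.29 log units; within the scatter) from compound 3 to compound 4, 1.3-fold (0.13 log units) apart, within the scatter of two such steps

Two pairs show only a shared direction, and a 1.9-fold lower number from compound 3 to compound 4 (0.29 log units; within the scatter) does not by itself exceed the scatter, so they give no rule for other cores. The location of the substituent still counts on the methyl side, with 3-methylphenyl in place of 4-methylphenyl giving a 3.3-fold higher number from compound 2 to compound 4 (0.51 log units; beyond the scatter), while 3-methylphenyl in place of 4-methoxyphenyl gives a 1.3-fold higher number from compound 1 to compound 4 (0.10 log units; within the scatter), which lies within the scatter.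

Open, as far as these compounds go, is how a hydroxy group, an amine or a carboxylic acid would read in the place of methyl or methoxy in this assay. Also open, from the compounds shown here alone, is whether the step holds in any other cell line.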